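This account rests on a few compounds, and the source may have more. Where it says the series, first, only, none or still open, it means among the compounds named here.

Among the compounds with values here, compound 1 `Nc1nc(N)c2cc(CSC(=S)N3CCN(c4ccc(O)cc4)CC3)ccc2n1` is the weaker of the two measured members of this pair: in a functional assay on MCF7 cells (Homo sapiens) for antiproliferative activity, read by MTT assay, with a stated time of 72 h (a higher number here means a weaker inhibitor, a lower number a stronger inhibitor), compound 1 gives 5090 nM, the highest of the two numbers, and its nearest neighbour is compound 2 `Nc1nc(N)c2cc(CSC(=S)N3CCN(c4ccc(F)cc4)CC3)ccc2n1`, which in this assay gives 1920 nM. Within the data shown here, the single measured step, a 2.7-fold lower number from compound 1 to compound 2 (0.42 log units; beyond the scatter), arises from fluoro in place of hydroxy on an aromatic carbon of the 4-hydroxyphenyl group.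

Compound 3 `CC(=O)c1ccc(N2CCN(C(=S)SCc3ccc4nc(N)nc(N)c4c3)CC2)cc1` is the next member awaiting a value. Relative to compound 1, the change is acetyl in place of hydroxy on an aromatic carbon. Among the measured compounds shown here, the same site was altered in the step from compound 1 to compound 2, where removing the hydroxy lowered the number modestly; that single step is the only guide available, and the acetyl group is not directly represented among the measured compounds. On that basis a lowering of similar size is expected, a 2.0-fold lower number from compound 1 to compound 3 (0.31 log units; beyond the scatter), with wide uncertainty. Compound 3 is estimated at 2500 nM in this assay, with a plausible range from 900 nM to 7000 nM.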

Compound 3, half-maximal inhibitory concentration: 2490 nM
For compound 3 the middle estimate is 1.0-fold (0.00 log units) above the measured one; the range from low to high includes it.
By their numbers in this assay, from the lowest: compounds 2 and 3 (each within the scatter of the next); then compound 1.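

In this assay, acetyl in place of hydroxy gives a 2.0-fold lower number from compound 1 to compound 3 (0.31 log units; beyond the scatter), so a second replacement at this position moves the number in the same direction as fluoro did. The two replacements cannot be told apart, with a 1.3-fold higher number from compound 2 to compound 3 (0.11 log units; within the scatter), so this series gives no order between fluoro and acetyl. Among these three compounds, only compound 1, the 4-hydroxyphenyl member, has steps beyond the scatter to both others.

Nothing at hand accounts for the separation of hydroxy from the other two groups. On these data alone, it remains open whether an amine, a carboxylic acid or a methoxy group at this position would fall with hydroxy or with fluoro and acetyl.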